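The compounds below may be only part of what the source reports. "The series", "measured", "known", "first", "only" and "open" are said of these compounds alone.

For the measured compounds named here, compound 2, `COc1cc(Cl)cc(-c2nn(-c3cccc(NC(=O)Nc4ccc(Cl)c(Cl)c4)c3)cc2-c2ccncc2)c1`, gives 60% in a functional assay on NCI-H522 cells (Homo sapiens) for inhibition, read by sulforhodamine B assay, with a stated time of 48 h, tested at 1 uM (a lower number here means a stronger effect, a higher number a weaker effect of the compound at the concentration tested), which is the higher of the two numbers known, so it is the weaker of the two measured compounds. Compound 1, `COc1cc(Cl)cc(-c2nn(-c3cccc(NC(=O)Nc4ccc(Cl)c(C(F)(F)F)c4)c3)cc2-c2ccncc2)c1`, gives 34% in this assay. Going by the values given here, the only measured step is a number 26 percentage points higher from compound 1 to compound 2 (beyond the scatter), where a chloro replaced a trifluoromethyl on an aromatic carbon.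

Compound 3, `COc1cc(Cl)cc(-c2nn(-c3cccc(NC(=O)Nc4cccc(C(F)(F)F)c4)c3)cc2-c2ccncc2)c1`, has not yet been measured. It differs from compound 2 by 3-(trifluoromethyl)phenyl in place of 3,4-dichlorophenyl on an amide-type nitrogen. This change brings a trifluoromethyl back onto the ring carried by the amide-type nitrogen, much as in compound 1, while the 3,4-dichlorophenyl and both of its chlorines leave. The step from compound 1 to compound 2 is the one that bears on it: swapping trifluoromethyl for chloro weakened the effect, so returning to trifluoromethyl is expected to pull the number back down, though the loss of the second chlorine leaves the outcome less certain. A modest fall, a number 15 percentage points lower from compound 2 to compound 3 (beyond the scatter), is expected. Compound 3 is therefore estimated at 45% in this assay, within a range from 25% to 65%.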

Compound 3, a percentage reported as activity, at one concentration (the size of the read-out at that concentration, not a potency): 33%
Estimate against measurement, compound 3: 12 percentage points above; low and high end bracket the measured number.
By their numbers in this assay, from the lowest: compounds 3 and 1 (each within the scatter of the next); then compound 2.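

Swapping 3,4-dichlorophenyl for 3-(trifluoromethyl)phenyl on the amide-type nitrogen gives a number 27 percentage points lower from compound 2 to compound 3 (beyond the scatter) in this assay, so this ring position responds to the change even when the trifluoromethyl group arrives without any chlorine. The chloro that compound 1 carries on this ring now has its own test: hydrogen in its place gives a number 1 percentage points lower from compound 1 to compound 3 (within the scatter), so the two compounds cannot be told apart in this assay. Among these three compounds, then, the two that carry trifluoromethyl sit together, and compound 2, the only one without it, gives the weakest effect at the concentration tested.

As far as these compounds go, it remains open whether trifluoromethyl is special here or whether another group on this ring, such as a methoxy, a nitrile or an amine, would give a number close to that of compound 3. Nothing among the data shown explains why the compounds with trifluoromethyl give the lower numbers.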